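The compounds below may be only part of what the source reports. "The series", "measured", "known", "first", "only" and "open" are said of these compounds alone.

Measured in an ADME assay on BaF3 cells (Mus musculus) for antiproliferative activity, read by CCK-8 assay, with a stated time of 72 h; a lower number here means a stronger inhibitor of growth, a higher number a weaker inhibitor of growth:
Compound 1 `O=C(CCSc1ccc2c(/C=C/c3ccccn3)n[nH]c2c1)Nc1cccc(F)c1`: 6590 nM
Compound 2 `COc1cccc(NC(=O)CCSc2ccc3c(/C=C/c4ccccn4)n[nH]c3c2)c1`: 3840 nM
Compound 3 `COc1ccc(NC(=O)CCSc2ccc3c(/C=C/c4ccccn4)n[nH]c3c2)cc1C(F)(F)F`: > 10000 nM (a limit)

Compound 3 has no number in this assay, only the limit > 10000 nM. Compound 4 `Cc1cn(Cc2ccc(NC(=O)CCSc3ccc4c(/C=C/c5ccccn5)n[nH]c4c3)cc2C(F)(F)F)cn1` carries (4-methyl-1H-imidazol-1-yl)methyl in place of methoxy on an aromatic carbon, ortho to a trifluoromethyl group: (4-methyl-1H-imidazol-1-yl)methyl in place of methoxy on an aromatic carbon. For the measured compounds named here, the only measured step, a 1.7-fold lower number from compound 1 to compound 2 (0.23 log units; within the scatter), also swaps a group on an aromatic carbon, but it stays within the scatter and involves different groups, so it is a weak guide. Compound 2 gives 3840 nM, which shows that the shared core can return a number in this assay. A move towards a lower number is expected, of uncertain size, and is estimated as an at least 3.3-fold lower number from compound 3 to compound 4 (0.52 log units; beyond the scatter). The estimate for compound 4 is 3000 nM, expected to lie between 400 nM and 12000 nM.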

Compound 4, concentration for 50% growth inhibition: 1990 nM
Beside the measured number, compound 4's estimate is 1.5-fold (0.18 log units) above it, and the stated range covers the measured number.
By their numbers in this assay, from the lowest: compounds 4, 2 and 1 (each within the scatter of the next, the first and the last beyond it). At a limit, above all of these: compound 3.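

In this assay, (4-methyl-1H-imidazol-1-yl)methyl in place of methoxy, on this aromatic carbon ortho to a trifluoromethyl group, gives an at least 5.0-fold lower number from compound 3 to compound 4 (0.70 log units; beyond the scatter). With the trifluoromethyl group kept, this position therefore carries a larger group with a ring and returns a number, which compound 3 did not. Compound 3 stands at a limit and not at a number, so the step is only a bound: the limit of > 10000 nM in this assay, at which 1 of the 4 values shown sits.

As far as these compounds go, it remains open whether the imidazole ring itself accounts for the step. A piperazine ring or a plain dimethylamine on the same methylene might serve equally well.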